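A few compounds are considered here, and "the series" means these few. Any claim that something is new, unique, unknown or untested is made for them only; others in the source may bear on it.

Measured compounds:
- Compound 1, `CN(C)c1ncnc2c1ncn2[C@@H]1O[C@H](CO[Si](C)(C)C(C)(C)C)[C@@]2(OS(=O)(=O)C=C2N)[C@H]1O[Si](C)(C)C(C)(C)C`, in a functional assay on MT4 cells (Homo sapiens) for cytotoxicity (on this read-out lower numbers stand for higher toxicity in this test and higher numbers for lower toxicity in this test), compound 1 gives 15000 nM.
- Compound 2, `COc1ccc(C(Nc2ncnc3c2ncn3[C@@H]2O[C@H](CO[Si](C)(C)C(C)(C)C)[C@]3(OS(=O)(=O)C=C3N)[C@H]2O[Si](C)(C)C(C)(C)C)(c2ccccc2)c2ccccc2)cc1`, in this assay compound 2 gives 191000 nM.
- Compound 3, `CC(C)(C)[Si](C)(C)OC[C@H]1O[C@@H](n2cnc3ncnc(O)c32)[C@H](O[Si](C)(C)C(C)(C)C)[C@]12OS(=O)(=O)C=C2N`, in this assay compound 3 gives 15000 nM.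

Compound 2 stands highest of the three in this assay, and both compound 1 and compound 3 lie beyond the scatter from it. Going by the values given here, the one measured step, no change at the digits printed from compound 1 to compound 3 (within the scatter), concerns the base and not the sugar part; it says nothing about configuration.

Compound 4, `COc1ccc(C(Nc2ncnc3c2ncn3[C@@H]2O[C@H](CO[Si](C)(C)C(C)(C)C)[C@@]3(OS(=O)(=O)C=C3N)[C@H]2O[Si](C)(C)C(C)(C)C)(c2ccccc2)c2ccccc2)cc1`, is not yet measured. It differs from compound 2 in this way: the two compounds have the same atoms and bonds and differ only in configuration as drawn: 1 of 4 stereo elements differ; a stereocentre at a saturated ring carbon is drawn S in compound 2 and R in compound 4. Among the compounds with values here, no measured step bears on a change of configuration at a saturated ring carbon, so the series gives no direction for this step. The working expectation is therefore no change beyond the scatter, with a wide range to cover the lack of precedent. For compound 4 the estimate in this assay is 191000 nM, with a range from 50000 nM to 500000 nM. The estimated step is no change at the digits printed from compound 2 to compound 4 (within the scatter).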

Compound 4, half-maximal cytotoxic concentration: 192000 nM
Compound 4: middle estimate off by 1.0-fold (0.00 log units), on the low side; the measured number falls inside the stated range.
By their numbers in this assay, from the lowest: compounds 1 and 3 (each within the scatter of the next); then compounds 2 and 4 (each within the scatter of the next).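

In this assay, going by these compounds alone, the first measured step that touches this saturated ring carbon is a 1.0-fold higher number from compound 2 to compound 4 (0.00 log units; within the scatter). The earlier compounds shown here gave no reading on configuration, whereas this pair ties the step to this one stereocentre, drawn S in compound 2 and R in compound 4: the fact that compounds 2 and 4 differ only in the configuration as drawn. With the base shared by compounds 2 and 4, inverting this centre therefore does not separate the two compounds on this read-out.

Whether the inversion behaves alike with the dimethylamino base of compound 1 or the base of compound 3 stays open, as each is shown in one configuration only. Also open, from the compounds shown here alone, is how either configuration reads with a primary amine on the base, or with a free hydroxyl in place of a silyl ether.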